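Cyclohexyl to Benzyl on the Amide Nitrogen

The compounds below may be only part of what the source reports. "The series", "measured", "known", "first", "only" and "open" are said of these compounds alone.

The series shares one core, seen in compound 1 `N[C@H]1CC[C@H](Nc2c(C(=O)NCc3cccs3)nc(Br)c3cccnc23)CC1` and compound 2 `CN(C)c1ccc(CNC(=O)c2nc(Br)c3cccnc3c2N[C@H]2CC[C@H](N)CC2)cc1`, which differ from each other only in the group carried on the amide nitrogen. In a functional assay on HCT-116 cells (Homo sapiens) for cytotoxicity, read by MTT assay, with a stated time of 72 h (a lower number here means a stronger inhibitor, a higher number a weaker inhibitor), compound 1 gives "not determined" (no result reported). In this assay compound 2 likewise gives "not determined" (no result reported). Among the compounds with values here, the one compound with a reported result is compound 3 `N[C@H]1CC[C@H](Nc2c(C(=O)NC3CCCCC3)nc(Br)c3cccnc23)CC1`. In this assay compound 3 reaches only a limit, > 10000 nM, so no number for it is known, and it sits at the limit of > 10000 nM in this assay, at which 1 of the 3 values shown sits.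

Compound 4 `N[C@H]1CC[C@H](Nc2c(C(=O)NCc3ccccc3)nc(Br)c3cccnc23)CC1` is the one not yet measured. It differs from compound 3 in a single place: benzyl in place of cyclohexyl on an amide-type nitrogen. The cyclohexyl leaves, a six-membered non-aromatic ring of carbon only, and benzyl enters, a six-membered aromatic ring of carbon only, with no change in hydrogen-bond donors, acceptors or net charge.

Within the data shown here, no measured pair in this set shows what such a change does, so the size of the step can only be estimated. She expects compound 4 to stay weak in this assay, with a step from compound 3 of about a number no higher from compound 3 to compound 4 (the limit leaves the size open), no larger than the usual scatter. Her estimate for compound 4 in this assay is 10000 nM, within a range from 3000 nM to 30000 nM, and it may well again come back only as a limit.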

Compound 4, half-maximal inhibitory concentration: 7000 nM
For compound 4 the middle estimate is 1.4-fold (0.15 log units) above the measured one, and the stated range covers the measured number.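

With benzyl on the amide nitrogen, compound 4 gives 7000 nM in this assay, the only single number among the compounds shown, and so gives this position a value that can be read rather than a limit. Replacing cyclohexyl with benzyl gives an at least 1.4-fold lower number from compound 3 to compound 4 (0.15 log units; that floor lies within the scatter), so the compounds shown do not establish a real gain from this change, although they do not exclude one. Compound 3 has only a limit, not a number, so the true size of the step stays open and the printed figure is only its floor: the limit of > 10000 nM in this assay, at which 1 of the 4 values shown sits.

Going by these compounds, compound 1 and compound 2 have no reported result, so any steps involving them cannot be read, and what their groups on the amide nitrogen do in this assay remains unknown. The compounds shown also leave open whether a carboxylic acid on the benzyl ring, or a longer chain in place of benzyl, would shift the number in this assay beyond the usual scatter.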